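Moving the chlorine on the benzyl ring: an estimate

A few compounds are considered here, and "the series" means these few. Any claim that something is new, unique, unknown or untested is made for them only; others in the source may bear on it.

Compound 1 `CC(C)(C)OC(=O)N1CCN(C(=S)SCc2cn(Cc3ccc(Cl)c(Cl)c3)nn2)CC1` and compound 2 `CC(C)(C)OC(=O)N1CCN(C(=S)SCc2cn(Cc3ccc(Cl)cc3)nn2)CC1` share one core and differ only in the chlorines on the benzyl ring. In a functional assay on ECa-109 cells (Homo sapiens) for inhibition, read by MTT assay, with a stated time of 72 h (on this read-out higher numbers stand for weaker inhibition and lower numbers for stronger inhibition), compound 1 gives > 128000 nM, which is a limit of the assay rather than a measured number. In this assay compound 2 likewise gives > 128000 nM, again a limit. The step that the two limits leave unreadable from compound 1 to compound 2 cannot be sized, since both values sit at the limit of > 128000 nM in this assay, at which 2 of the 2 values shown sit. Compound 2 thus stands at the boundary of what this assay reports, with no number of its own.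

Compound 3 `CC(C)(C)OC(=O)N1CCN(C(=S)SCc2cn(Cc3ccccc3Cl)nn2)CC1` has not yet been measured. It differs from compound 2 by 2-chlorophenyl in place of 4-chlorophenyl on a saturated chain carbon bound to an aromatic nitrogen. For the measured compounds named here, no measured step bears directly on this rearrangement, and the one step that exists is unreadable, so neither a direction nor a size beyond the scatter can be drawn from the data. With both measured compounds at the limit, compound 3 is expected to show a step that the limit leaves unreadable from compound 2 to compound 3 in this assay, meaning no change. Compound 3 is therefore estimated at 150000 nM, with a range from 60000 nM to 400000 nM, and this assay will most likely again report only a limit.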

Compound 3, half-maximal inhibitory concentration: 11900 nM
Estimate against measurement, compound 3: 13-fold (1.10 log units) above; the whole stated range lies above it.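

In this assay, where the chlorine sits on the benzyl ring clearly matters: 2-chlorophenyl in place of 4-chlorophenyl, on a saturated chain carbon bound to an aromatic nitrogen and with the same atoms joined differently, gives an at least 10-fold lower number from compound 2 to compound 3 (1.03 log units; beyond the scatter). At the same place, 2-chlorophenyl in place of 3,4-dichlorophenyl gives an at least 10-fold lower number from compound 1 to compound 3 (1.03 log units; beyond the scatter), so the two steps together tie the gain to the 2-chlorophenyl group, while the step between compound 1 and compound 2 cannot be read. This position now has a measurable response for the first time, and compound 3 alone has a number of its own, with the other two compounds still at a limit: the limit of > 128000 nM in this assay, at which 2 of the 3 values shown sit.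

The compounds shown leave open whether the gain depends on chlorine itself or on having any group at that ring position, a question that 2-fluorobenzyl, 2-methoxybenzyl or plain benzyl would help to answer. Going by these compounds, it is also open whether the 2-chlorobenzyl effect would hold if a free amine replaced the tert-butyl ester end of the shared core.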